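The source may hold more compounds than are shown below. What is called first, only, known or untested is meant among the compounds shown, and "the series" means these compounds.

Measured so far in an ADME assay on HepG2 cells (Homo sapiens) for cytotoxicity, read by luminescence, CellTiter-Glo and ATP content, with a stated time of 72 h; a lower number here means that less compound is needed, a higher number that more compound is needed for the effect:
Compound 1 `COc1cccc(CNCCCNc2ccnc3cc(Cc4cc(C)cc(C)c4)ccc23)c1O` gives 2680 nM.
Compound 2 `COc1cccc(CNCCCNc2ccnc3cc(Oc4ccc(F)cc4)ccc23)c1O` gives 11000 nM.
Compound 3 `COc1ccccc1Oc1ccc2c(NCCCNCc3cccc(OC)c3O)ccnc2c1` gives 11200 nM.

Compound 3 stands at the highest of the three numbers, though compound 2 sits within the scatter of it: a 1.0-fold higher number from compound 2 to compound 3 (0.01 log units; within the scatter). Compound 1 lies further off, with a 4.2-fold higher number from compound 1 to compound 3 (0.62 log units; beyond the scatter) and a 4.1-fold higher number from compound 1 to compound 2 (0.61 log units; beyond the scatter).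

Compound 4 `COc1cccc(CNCCCNc2ccnc3cc(Oc4ccc(Cl)cc4)ccc23)c1O` differs from compound 3 by 4-chlorophenyl in place of 2-methoxyphenyl on an oxygen on an aromatic ring. Among the measured compounds shown here, the one step that bears on this change is the one from compound 2, which carries 4-fluorophenoxy, to compound 3, a 1.0-fold higher number from compound 2 to compound 3 (0.01 log units; within the scatter), within the scatter. On that basis no step beyond the scatter is expected in this assay from compound 3 to compound 4, a 1.1-fold lower number from compound 3 to compound 4 (0.05 log units; within the scatter). Compound 4 is therefore expected to give about 10000 nM, with a range of 4000 nM to 25000 nM.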

Compound 4, half-maximal effective concentration: 5700 nM
Estimate against measurement, compound 4: 1.8-fold (0.24 log units) above; low and high end bracket the measured number.
By their numbers in this assay, from the lowest: compound 1; then compounds 4, 2 and 3 (each within the scatter of the next).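

In this assay, chloro in place of fluoro on the aromatic carbon stays within the scatter (a 1.9-fold lower number from compound 2 to compound 4 (0.29 log units; within the scatter)), as does 4-chlorophenyl in place of 2-methoxyphenyl on the oxygen (a 2.0-fold lower number from compound 3 to compound 4 (0.29 log units; within the scatter)). The change from 3,5-dimethylbenzyl to 4-chlorophenoxy remains beyond the scatter, though modest (a 2.1-fold higher number from compound 1 to compound 4 (0.33 log units; beyond the scatter)), so compound 2, compound 3 and compound 4 all give higher numbers than compound 1. No measurement at hand accounts for these steps.

From the compounds shown here alone, whether an amine or a carboxylic acid on the phenoxy ring would shift the number beyond the scatter remains open. The shown compounds also cannot separate the oxygen link from the ring substituents in the step away from compound 1.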